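Amide in place of urea on the amine nitrogen

The source may report more compounds than this note shows. Statements on the series, on what has been measured and on what is new or still open speak of the compounds shown alone.

Compound 1 `NC[C@@H]1CCCc2cc(S(=O)(=O)c3cccc(F)c3)ccc21` gives 0.0794 nM in an assay on isolated protein for displacement of a labelled ligand from 5-hydroxytryptamine receptor 6 (Homo sapiens); a lower number here means a stronger inhibitor, a higher number a weaker inhibitor. Compound 2 `O=C1CN=C(NC[C@@H]2CCCc3cc(S(=O)(=O)c4cccc(F)c4)ccc32)N1` gives 0.1 nM. Compound 3 `CN(C)C(=O)NC[C@@H]1CCCc2cc(S(=O)(=O)c3cccc(F)c3)ccc21` gives 2.51 nM.

Compound 3 stands highest of the three numbers: a 32-fold higher number from compound 1 to compound 3 (1.50 log units; beyond the scatter) and a 25-fold higher number from compound 2 to compound 3 (1.40 log units; beyond the scatter). Compound 4 `CC(=O)N(C)C[C@@H]1CCCc2cc(S(=O)(=O)c3cccc(F)c3)ccc21` differs from compound 3 by acetyl(methyl)amino in place of (dimethylcarbamoyl)amino on a saturated chain carbon bound to a saturated ring carbon. Among the compounds with values here, no measured step changes a group already bound on that amine nitrogen; the two steps that reach compound 3 only show that dimethylcarbamoyl on the nitrogen raised the number strongly relative to hydrogen or the ring group. Compound 4 keeps an acyl group there and loses the donor, so a modest rise is expected, a 2.0-fold higher number from compound 3 to compound 4 (0.30 log units; within the scatter), with wide uncertainty. Compound 4 is estimated at 5 nM, in the range 1.2 nM to 25 nM.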

Compound 4, inhibition constant: 1.59 nM
The estimate for compound 4 lay 3.1-fold (0.50 log units) above the measured number; measured number inside the range.
By their numbers in this assay, from the lowest: compounds 1 and 2 (each within the scatter of the next); then compounds 4 and 3 (each within the scatter of the next).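

The change from (dimethylcarbamoyl)amino to acetyl(methyl)amino on this saturated chain carbon gives a 1.6-fold lower number from compound 3 to compound 4 (0.20 log units; within the scatter) and so does not separate the two groups, although acetyl(methyl)amino has no hydrogen-bond donor. The large gap to the amino compound and the ring compound remains, with a 20-fold higher number from compound 1 to compound 4 (1.30 log units; beyond the scatter) and a 16-fold higher number from compound 2 to compound 4 (1.20 log units; beyond the scatter) on record for this group. Nothing available explains these steps. Still open, from the compounds shown here alone, is whether a methylamino group, without the acetyl, or a longer acyl chain such as butanoyl would fall with compound 1 or with compound 4.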